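Fluoro added to the benzyl thioether of compound 3

A few compounds are considered here, and "the series" means these few. Any claim that something is new, unique, unknown or untested is made for them only; others in the source may bear on it.

Working notes on three measured thioethers and one still to come. In an assay on isolated protein for inhibition of Ca2+/calmodulin-dependent protein kinase II (CaM kinase II) (Rattus norvegicus), tested at 30 uM (a higher number here means more inhibition at the concentration tested (going by the name of the read-out), a lower number less inhibition), compound 1 `Cn1cnc2c(Sc3ccccc3)ncnc21` gives 8%. Compound 2 `c1ccc(CSc2ncnc3[nH]cnc23)cc1` gives 0% in this assay, and compound 3 `Cn1cnc2c(SCc3ccccc3)ncnc21` gives 0%. Among the compounds with values here, the only step measured so far, methyl in place of hydrogen on an aromatic nitrogen, comes out as no change at the digits printed from compound 2 to compound 3 (within the scatter). Compound 3 therefore stands level with compound 2 at the digits shown, and the gap to compound 1 lies within the scatter, so the three numbers do not separate from one another.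

Compound 4 `Cn1cnc2c(SCc3ccc(F)cc3)ncnc21` differs from compound 3 by fluoro in place of hydrogen on an aromatic carbon. Within the data shown here, no measured step touches a substituent on the six-membered aromatic ring of carbon only; the single measured step concerns a different position and was flat. Nothing in the data points to a step in this assay beyond the scatter in either direction, and the expected step is a number 2 percentage points higher from compound 3 to compound 4 (within the scatter). Compound 4 is accordingly expected to give 2% in this assay, in a range from -8% to 12%.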

Compound 4, a percentage reported as inhibition, at one concentration (the size of the read-out at that concentration, not a potency): 5%
For compound 4 the middle estimate is 3 percentage points below the measured one, and the stated range covers the measured number.
By their numbers in this assay, from the lowest: compounds 2, 3, 4 and 1 (each within the scatter of the next).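

In this assay, within the data shown here, this is the first measured change on the six-membered aromatic ring of carbon only: fluoro in place of hydrogen, para to a large group, gives a number 5 percentage points higher from compound 3 to compound 4 (within the scatter). The earlier step, methyl in place of hydrogen on an aromatic nitrogen, gave no change at the digits printed from compound 2 to compound 3 (within the scatter), so a change on the benzyl ring has now been tested as well, and neither single change moves the read-out beyond the scatter. At this position, fluoro therefore cannot be told apart from hydrogen at the concentration tested, and no evidence bears on the reason for this result.

It remains open whether any other group at this place would separate from hydrogen, since trifluoromethyl, methoxy, an amine and a carboxylic acid on the same ring are not among the compounds shown. A longer chain in place of the benzyl group, and fluoro on the phenyl thioether of compound 1, are likewise absent, so the series gives no reading on either change.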